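Replacing Isopropyl with 3-Chlorophenyl on the Shared Core

The source may report more compounds than this note shows. Statements on the series, on what has been measured and on what is new or still open speak of the compounds shown alone.

In a functional assay on MDA-MB-231 cells (Homo sapiens) for antiproliferative activity, read by MTT assay, with a stated time of 72 h (a lower number here means a stronger inhibitor, a higher number a weaker inhibitor), compound 1 `O=C(CCc1cccc2c1B(O)OC2)Nc1cccc(Br)c1` gives 720 nM, while compound 2 `CC(C)c1cccc(NC(=O)CCc2cccc3c2B(O)OC3)c1` gives 1600 nM, the higher of the two numbers. Compound 3 `O=C(CCc1cccc2c1B(O)OC2)Nc1cccc(-c2cccc(Cl)c2)c1` carries 3-chlorophenyl in place of isopropyl on an aromatic carbon. Going by the values given here, only one measured step bears on this change, the modest 2.2-fold higher number from compound 1 to compound 2 (0.35 log units; beyond the scatter), which also alters this aromatic carbon. Among the compounds with values here, no measured compound carries a ring there, so the guidance is thin. A similarly modest move toward a lower number is therefore expected in this assay, and the estimated step is a 2.1-fold lower number from compound 2 to compound 3 (0.33 log units; beyond the scatter). For compound 3 the expected value is 750 nM, within an estimated range of 200 nM to 2500 nM.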

Compound 3, half-maximal inhibitory concentration: 250 nM
The estimate for compound 3 lay 3.0-fold (0.48 log units) above the measured number; the range from low to high includes it.
By their numbers in this assay, from the lowest: compound 3; then compound 1; then compound 2.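

Going by these compounds alone, the first ring at this aromatic carbon gives the lowest number so far in this assay, with 3-chlorophenyl improving on isopropyl (a 6.4-fold lower number from compound 2 to compound 3 (0.81 log units; beyond the scatter)) and also on bromo (a 2.9-fold lower number from compound 1 to compound 3 (0.46 log units; beyond the scatter)). Both steps lie beyond the scatter, so this position accepts an aromatic ring and does not simply favour the smaller groups seen earlier. Nothing available explains this gain. Whether the ring itself or its chlorine accounts for the step remains open. So does the effect of an amine, a carboxylic acid or a longer chain on this carbon.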